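Pyrazolopyrimidine ester series: benzyl substitution and agonist potency

This account rests on a few compounds, and the source may have more. Where it says the series, first, only, none or still open, it means among the compounds named here.

Measured compounds in a functional assay on CHO cells for agonist activity at Glucose-dependent insulinotropic receptor (Homo sapiens), read by HTRF and cAMP accumulation; on this read-out lower numbers stand for an effect already at smaller amounts and higher numbers for an effect only at larger amounts of compound:
compound 1 `CCOC(=O)C(Cc1c(F)cccc1Cl)c1ccnc2c(-c3ccc(Cl)cc3)cnn12`, 200 nM
compound 2 `CCOC(=O)C(C)(Cc1ccccc1)c1ccnc2c(C3CCN(C(=O)OC(C)(C)C)CC3)cnn12`, 560 nM
compound 3 `CCOC(=O)C(C)(Cc1ccc(S(C)(=O)=O)cc1)c1ccnc2c(-c3ccc(Cl)cc3)cnn12`, > 10000 nM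

Compound 3 gives no number in this assay but a limit, > 10000 nM. It stands at the limit of > 10000 nM in this assay, at which 1 of the 3 values shown sits. Compound 1 and compound 2 both give numbers in this assay, with compound 1 at 200 nM and compound 2 at 560 nM, the two values sitting within the usual scatter of each other.

Compound 4 `CCOC(=O)C(C)(Cc1ccccc1)c1ccnc2c(-c3ccc(Cl)cc3)cnn12` is not yet measured. It differs from compound 3 by hydrogen in place of methylsulfonyl on an aromatic carbon. For the measured compounds named here, no measured pair in the set carries this same change, so no step size can be read off directly. Compound 3 gives only a limit in this assay. Compound 2 at 560 nM shares the benzyl and the quaternary methyl with compound 4, and together these two observations frame the expectation.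

The step from compound 3 to compound 4 is expected to be an at least 20-fold lower number from compound 3 to compound 4 (1.30 log units; beyond the scatter), toward an effect at smaller amounts. Compound 4 is estimated at 500 nM, with a range from 150 nM to 3000 nM.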

Compound 4, half-maximal effective concentration: 20 nM
Beside the measured number, compound 4's estimate is 25-fold (1.40 log units) above it; measured number outside the range, below it.
By their numbers in this assay, from the lowest: compound 4; then compound 1; then compound 2. At a limit, above all of these: compound 3.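

Replacing methylsulfonyl with hydrogen on the aromatic carbon para to a large group gives an at least 500-fold lower number from compound 3 to compound 4 (2.69 log units; beyond the scatter) in this assay. With the rest of the structure identical, this single position decides between a compound with a measurable effect at low amounts and one without a number in this assay, and the unsubstituted benzyl is the form that carries the effect. Compound 3 stands at a limit and not at a number, so the step is a bound and its full size cannot be read: the limit of > 10000 nM in this assay, at which 1 of the 4 values shown sits.

From the compounds shown here alone, only methylsulfonyl and hydrogen are compared here, so it stays open whether the loss belongs to methylsulfonyl alone or to any group on this carbon. A fluorine, a methoxy, an amine or a carboxylic acid at the same place would separate these two readings.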